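Pyridin-3-yl in place of phenyl on a carbonyl carbon

A few compounds are considered here, and "the series" means these few. Any claim that something is new, unique, unknown or untested is made for them only; others in the source may bear on it.

Of the compounds shown here, three sharing one core have been measured in a functional assay on HCT-15 cells (Homo sapiens) for antiproliferative activity; on this read-out lower numbers stand for stronger inhibition and higher numbers for weaker inhibition. Compound 3 (`COc1ccc(S(=O)(=O)Oc2ccccc2NC(=O)c2ccccc2)cc1`), which carries phenyl on the carbonyl carbon, gives 310 nM, the highest number of the three. Compound 1 (`COc1ccc(S(=O)(=O)Oc2ccccc2NC(=O)c2ccccn2)cc1`), with pyridin-2-yl at that place, gives 110 nM, and compound 2 (`COc1ccc(S(=O)(=O)Oc2ccccc2NC(=O)c2ccco2)cc1`), with furan-2-yl, gives 19 nM.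

Compound 4 (`COc1ccc(S(=O)(=O)Oc2ccccc2NC(=O)c2cccnc2)cc1`) is still unmeasured. It has pyridin-3-yl in place of phenyl on a carbonyl carbon.

The closest measured guide is a 2.8-fold higher number from compound 1 to compound 3 (0.45 log units; beyond the scatter), a modest step that links phenyl to the other pyridine group in the set. Read in reverse, it points toward a lower number when a pyridine group replaces phenyl. The larger 16-fold higher number from compound 2 to compound 3 (1.21 log units; beyond the scatter) bears on the change less directly, since it involves furan-2-yl rather than a pyridine group. For the measured compounds named here, no measurement yet shows how pyridin-3-yl itself compares with pyridin-2-yl, so the guide is only partial and the range must stay wide.

The expected step is therefore small and toward a lower number: a 1.8-fold lower number from compound 3 to compound 4 (0.26 log units; within the scatter). In this assay compound 4 is estimated at 170 nM, with an expected range of 60 nM to 480 nM.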

Compound 4, half-maximal inhibitory concentration: > 3000 nM
Compound 4 was reported as a limit; the forecaster's own chance of this, stated with the estimate: 2%; at least 17-fold (1.24 log units) between middle value and limit.
By their numbers in this assay, from the lowest: compound 2; then compound 1; then compound 3. At a limit, above all of these: compound 4.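

Compound 4 is recorded in this assay only as a limit, > 3000 nM, and it is the only compound shown there: the limit of > 3000 nM in this assay, at which 1 of the 4 values shown sits.

The earlier compounds shown here suggested that a pyridine group on this carbonyl carbon could improve on phenyl, but pyridin-3-yl goes the other way, with an at least 9.6-fold higher number from compound 3 to compound 4 (0.98 log units; beyond the scatter). The two pyridine groups are therefore not interchangeable at this place, even though they differ only in where the ring carries its nitrogen: the change gives an at least 27-fold higher number from compound 1 to compound 4 (1.43 log units; beyond the scatter). The gap to furan-2-yl is wider still, with an at least 150-fold higher number from compound 2 to compound 4 (2.19 log units; beyond the scatter), so this single position spans a very wide range in this assay among the four groups shown, and the presence of a ring nitrogen alone does not set the direction of the change.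

Because compound 4 is held at a limit, the true size of these steps stays unknown, and the compounds shown do not say how far its number lies past that limit. They also leave open whether pyridin-4-yl would side with pyridin-2-yl or pyridin-3-yl, and whether thiophen-2-yl would keep the low number of compound 2.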